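The compounds below may be only part of what the source reports. "The series", "measured", "known", "first", "only" and "open" are said of these compounds alone.

In a functional assay on HepG2 cells (Homo sapiens) for cytotoxicity, read by MTT assay, with a stated time of 48 h (a lower number here means a stronger inhibitor, a higher number a weaker inhibitor), three compounds have been measured so far. Compound 1 `CCCCCCCCCCCCCCCCCCNC(=O)[C@@H](N)[C@@H](C)O` gives 44500 nM, which places it second highest of the three numbers. Compound 2 `C/C=C/C=C/C(=O)N[C@H](C(=O)NCCCCCCCC)[C@@H](C)O` gives 102000 nM, a higher number than compound 1 by a margin beyond the scatter, while compound 3 `CCCCCCCCCCCCCCNC(=O)[C@@H](NC(=O)c1cc2ccccc2[nH]1)[C@@H](C)O` gives 10500 nM, a lower number than compound 1, again beyond the scatter.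

Compound 4 `CCCCCCCCCCCCCCCCCCNC(=O)[C@@H](NC(=O)c1ccco1)[C@@H](C)O` has not yet been measured in this assay. It differs from compound 1 in one place: (furan-2-yl)carbonyl in place of hydrogen on an amine nitrogen. Among the measured compounds shown here, no pair of measured compounds differs by just this change, so no step of that kind is known. For the measured compounds named here, compound 3 also carries an aromatic carbonyl group on the amine nitrogen, and its value lies below that of compound 1, but compound 3 differs from compound 1 in its chain as well, so the two values show only that such a compound can give a lower number.

On that basis the step of a 2.2-fold lower number from compound 1 to compound 4 (0.35 log units; beyond the scatter) is expected to be a moderate decrease, beyond the scatter. The estimate for compound 4 is therefore 20000 nM, expected to fall between 8000 nM and 50000 nM.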

Compound 4, half-maximal inhibitory concentration: 42300 nM
For compound 4 the middle estimate is 2.1-fold (0.33 log units) below the measured one; the range from low to high includes it.
By their numbers in this assay, from the lowest: compound 3; then compounds 4 and 1 (each within the scatter of the next); then compound 2.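

In this assay, among the compounds shown here, putting (furan-2-yl)carbonyl in place of hydrogen on the amine nitrogen gives a 1.1-fold lower number from compound 1 to compound 4 (0.02 log units; within the scatter), and this is the first step that changes one place only. It shows that the amino group of compound 1 can become ((furan-2-yl)carbonyl)amino, adding a five-membered aromatic ring and 7 heavy atoms, with no change in the number beyond the scatter, so an aromatic carbonyl group on this nitrogen is not by itself enough to shift the reading on this chain. Nothing measured here gives a reason for this result.

As far as these compounds go, it remains open whether other groups on the same nitrogen, such as an acetyl, a benzoyl or a thiophene-2-carbonyl group, would also leave the number within the scatter of compound 1. Also open is whether (furan-2-yl)carbonyl would give the same step on a shorter or a longer chain, since the compounds shown include no pair that differs in the chain alone.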